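Chloro to Hydrogen on the Aryl Ring: Expected Step

A few compounds are considered here, and "the series" means these few. Any claim that something is new, unique, unknown or untested is made for them only; others in the source may bear on it.

Compound 1 `Cc1nc(-c2ccccc2)sc1C(=O)CSc1nc(-c2cccc(Cl)c2)c(C#N)c(=O)[nH]1` and compound 2 `COc1ccc(-c2nc(C)c(C(=O)CSc3nc(-c4ccc(Cl)c(Cl)c4)c(C#N)c(=O)[nH]3)s2)cc1` share one core. In a functional assay on U-87MG ATCC cells for antiproliferative activity against U-87 MG (Homo sapiens), read by MTT assay, with a stated time of 48 h, tested at 10 uM (a higher number here means a weaker effect of the compound at the concentration tested, a lower number a stronger effect), compound 1 gives 83.7%, and compound 2 gives 88.6%. On these two numbers compound 2 stands highest, with compound 1 nearest and within the scatter of it. Compound 3 `COc1ccc(-c2nc(C)c(C(=O)CSc3nc(-c4cccc(Cl)c4)c(C#N)c(=O)[nH]3)s2)cc1` differs from compound 2 by hydrogen in place of chloro on an aromatic carbon. Going by the values given here, no step between measured compounds is known, so the size of this step rests only on the fact that compound 1, which also carries 3-chlorophenyl, gives 83.7%, within the scatter of compound 2. The step expected for compound 3 is small, a number 3.6 percentage points lower from compound 2 to compound 3 (within the scatter), none beyond the scatter. Compound 3 is therefore estimated at 85%, between 72% and 96%.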

Compound 3, a percentage reported as activity, at one concentration (the size of the read-out at that concentration, not a potency): 90.6%
For compound 3 the middle estimate is 5.6 percentage points below the measured one; measured number inside the range.
By their numbers in this assay, from the lowest: compounds 1, 2 and 3 (each within the scatter of the next).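

In this assay the change from 3,4-dichlorophenyl to 3-chlorophenyl gives a number 2 percentage points higher from compound 2 to compound 3 (within the scatter), so hydrogen and chloro at this place cannot be told apart on these numbers. Methoxy in place of hydrogen on an aromatic carbon gives a number 6.9 percentage points higher from compound 1 to compound 3 (within the scatter), so that change does not separate compound 1 from compound 3 either. No measured data bear on the reason for either step. From the compounds shown here alone, whether an amine or a carboxylic acid in place of this chloro would give a step beyond the scatter stays open. Also open, going by these compounds, is whether any single change to the shared core would do so.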